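Methyl in Place of Fluoro on Compound 2

A few compounds are considered here, and "the series" means these few. Any claim that something is new, unique, unknown or untested is made for them only; others in the source may bear on it.

Among the compounds with values here, compound 2 `Cc1ccc(-c2ccncc2F)c(C(=O)N2CCC(O)(Cc3ccccc3)CC2)c1` holds the only plain number given in an assay for inhibition of cholesterol 24-hydroxylase (Homo sapiens), using NADPH, with stated times of 15 min and 5 min (a higher number here means a weaker inhibitor, a lower number a stronger inhibitor), at 17 nM. Compound 1 `Cc1ccc(-c2ccnc(C)c2)c(C(=O)N2CCC(O)(Cc3ccccc3)CC2)c1` reaches only a limit in this assay, > 10000 nM (the limit of > 10000 nM in this assay, at which 1 of the 2 values shown sits). Within the data shown here, the one measured step, an at least 580-fold lower number from compound 1 to compound 2 (2.76 log units; beyond the scatter), swaps one pyridinyl group for another. Compound 3 `Cc1ccc(-c2ccncc2C)c(C(=O)N2CCC(O)(Cc3ccccc3)CC2)c1` differs from compound 2 by methyl in place of fluoro on an aromatic carbon. That measured step changed both the group and its place, so it bears on compound 3 only loosely; a modest step in either direction, possibly none beyond the scatter, is expected in this assay. Compound 3 is therefore expected at 50 nM, between 10 nM and 500 nM. That estimate means a step of a 2.9-fold higher number from compound 2 to compound 3 (0.47 log units; beyond the scatter).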

Compound 3, half-maximal inhibitory concentration: 4.9 nM
Compound 3: middle estimate off by 10-fold (1.01 log units), on the high side; measured number below the stated range.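

In this assay, methyl at this place gives a stronger inhibitor than fluoro, with a 3.5-fold lower number from compound 2 to compound 3 (0.54 log units; beyond the scatter), so both groups are accepted here. Where the methyl sits matters far more than which of the two groups is present: 3-methylpyridin-4-yl in place of 2-methylpyridin-4-yl gives an at least 2000-fold lower number from compound 1 to compound 3 (3.30 log units; beyond the scatter). Compound 1 stands only at a limit: the limit of > 10000 nM in this assay, at which 1 of the 3 values shown sits. From the compounds shown here alone, whether a chloro, a methoxy or an amine at this same place would keep the number low remains open, and so does how a plain hydrogen there would compare.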